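The source may report more compounds than this note shows. Statements on the series, on what has been measured and on what is new or still open speak of the compounds shown alone.

Working notes on the series. Among the measured compounds shown here, compound 1 `Cn1cc(/C=C/C(=O)NS(=O)(=O)c2cc(F)c(F)cc2F)c2c(Oc3ccc4ccccc4c3)cccc21` is the reference point; in an assay on isolated protein for displacement of a labelled ligand from prostaglandin E2 receptor EP3 subtype (Homo sapiens), tested at 20 uM, in the presence of a further agent that is not named here (on this read-out higher numbers stand for weaker inhibition and lower numbers for stronger inhibition), compound 1 gives 9.2 nM, the lower of the two numbers so far. Its nearest neighbour is compound 2 `Cn1cc(/C=C/C(=O)NS(=O)(=O)c2cccc(Cl)c2)c2c(Oc3ccc4ccccc4c3)cccc21`, which in this assay gives 15.7 nM; the step of a 1.7-fold higher number from compound 1 to compound 2 (0.23 log units; within the scatter) is within the scatter, so the two cannot be ordered. That step concerns 3-chlorophenyl in place of 2,4,5-trifluorophenyl on a sulfonyl sulfur and leaves the rest of the shared core untouched.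

Compound 3 `Cn1cc(/C=C/C(=O)NS(=O)(=O)c2cc(F)c(F)cc2F)c2c(Oc3ccc(Cl)cc3Cl)cccc21` differs from compound 1 elsewhere: 2,4-dichlorophenyl in place of naphthalen-2-yl on an oxygen on an aromatic ring. For the measured compounds named here, no measured pair changes this aryloxy group, so nothing recorded bears directly on the step. Going by the values given here, the one measured step stays within the scatter, and the series offers no sign of large swings yet. Compound 3 is therefore expected to land near compound 1 with wide uncertainty, the step of a 2.7-fold higher number from compound 1 to compound 3 (0.43 log units; beyond the scatter) being an estimate only. The expected value for compound 3 in this assay is 25 nM, with a range from 6 nM to 100 nM.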

Compound 3, half-maximal inhibitory concentration: 3.2 nM
For compound 3 the middle estimate is 7.8-fold (0.89 log units) above the measured one; measured number below the stated range.
By their numbers in this assay, from the lowest: compound 3; then compounds 1 and 2 (each within the scatter of the next).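

In this assay, among the compounds shown here, the aryloxy group is the first place where a change gives a step beyond the scatter: the change to 2,4-dichlorophenyl gives a 2.9-fold lower number from compound 1 to compound 3 (0.46 log units; beyond the scatter), a modest step. The naphthalen-2-yl group, with its two aromatic rings, is therefore not required for a low number on this core, as a single ring with two chlorines does at least as well with fewer heavy atoms. Nothing on hand accounts for this step.

The compounds shown leave open whether the lower number follows from the loss of the second ring or the entry of the chlorines, a question that a plain phenyl or a monochlorophenyl on the same oxygen would separate. Also open, going by these compounds, is whether the step carries over to the 3-chlorophenyl on the sulfonyl sulfur, and how a pyridine ring would fare on that oxygen.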